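Series notes: aryl hydrazone core, whole-animal read-out

The source may hold more compounds than are shown below. What is called first, only, known or untested is meant among the compounds shown, and "the series" means these compounds.

The compounds share one core, seen in compound 1 `CC1CCC(=NNc2ccccc2C(=O)O)c2ncc(C(=O)NO)c(=O)n21`, compound 2 `Cc1cc(C)cc(NN=C2CCC(C)n3c2ncc(C(=O)O)c3=O)c1` and the still unmeasured compound 3 `CC1CCC(=NNc2cc(Cl)ccc2O)c2ncc(C(=O)O)c(=O)n21`. The read-out is a functional assay on the whole organism with Rattus norvegicus as the target; on this read-out higher numbers stand for an effect only at larger amounts of compound and lower numbers for an effect already at smaller amounts. In this assay compound 1 gives > 100 umol/kg, which is a limit of the assay and not a number. In this assay compound 2 gives > 320 umol/kg, again a limit and not a number. Within the data shown here, compound 2 thus stands at the limit of > 320 umol/kg in this assay, at which 1 of the 2 values shown sits, while compound 1 sits at the limit of > 100 umol/kg in this assay, at which 1 of the 2 values shown sits; neither limit yields a figure that would order the two, and the pair differs in more than one place, so no measured step links them.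

Compound 3 differs from compound 2 by 5-chloro-2-hydroxyphenyl in place of 3,5-dimethylphenyl on an amine nitrogen. Among the measured compounds shown here, both measured compounds stop at limits, so there is no measured step to lean on. The expected step of an at least 1.0-fold lower number from compound 2 to compound 3 (0.02 log units; that floor lies within the scatter) is none beyond the scatter, with a limit again the more likely outcome. Compound 3 is therefore estimated at 300 umol/kg, in the range 60 umol/kg to 1000 umol/kg.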

Compound 3, dose for 50% inhibition: > 100 umol/kg
Compound 3: no number, only a limit; the forecaster's own chance of this, stated with the estimate: 80%; the middle value is on the limit's open side.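

Compound 3 gives > 100 umol/kg in this assay, a limit and not a number. Among these compounds, compound 2 also stands at a limit, > 320 umol/kg, so no step from compound 2 to compound 3 can be read. The compounds shown leave open how 5-chloro-2-hydroxyphenyl and 3,5-dimethylphenyl on an amine nitrogen compare, and whether any compound in this series gives a number in this assay.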